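The source may report more compounds than this note shows. Statements on the series, on what has been measured and on what is new or still open speak of the compounds shown alone.

Measured compounds:
- Compound 1, `CC(=O)Nc1c(C)c(C(OC(C)(C)C)C(=O)O)c(-c2ccc(C)c(C)c2)c(C)c1-c1ccc(C)c(C)c1`, in an ADME assay on MT4 cells (Homo sapiens) for cytotoxicity, read by MTT assay, with a stated time of 4 days (on this read-out higher numbers stand for lower toxicity in this test and lower numbers for higher toxicity in this test), gives 19000 nM.
- Compound 2, `CCC(=O)Nc1c(C)c(C(OC(C)(C)C)C(=O)O)c(-c2ccc(C)c(C)c2)c(C)c1-c1ccc(C)c(C)c1`, in this assay gives 15000 nM.

Going by the values given here, on these two numbers compound 2 stands lowest, and its nearest neighbour is compound 1; the one measured step, a 1.3-fold lower number from compound 1 to compound 2 (0.10 log units; within the scatter), lies within the scatter, so the two values cannot be ordered.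

Compound 3, `CCNC(=O)Nc1c(C)c(C(OC(C)(C)C)C(=O)O)c(-c2ccc(C)c(C)c2)c(C)c1-c1ccc(C)c(C)c1`, differs from compound 2 by ethylamino in place of ethyl on a carbonyl carbon. Among the compounds with values here, no measured step exchanges ethyl for ethylamino, so nothing bears on it directly; the only step at hand, a 1.3-fold lower number from compound 1 to compound 2 (0.10 log units; within the scatter), alters the same chain and is within the scatter. The expectation for compound 3 in this assay is therefore a step of a 1.1-fold higher number from compound 2 to compound 3 (0.05 log units; within the scatter), that is, none beyond the scatter. Compound 3 is estimated at 17000 nM, with a range from 7000 nM to 40000 nM.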

Compound 3, half-maximal cytotoxic concentration: 15000 nM
Compound 3: middle estimate off by 1.1-fold (0.05 log units), on the high side, within the range that was stated.
By their numbers in this assay, from the lowest: compounds 2, 3 and 1 (each within the scatter of the next).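

In this assay ethylamino in place of ethyl on a carbonyl carbon gives no change at the digits printed from compound 2 to compound 3 (within the scatter) and ethylamino in place of methyl on that carbon gives a 1.3-fold lower number from compound 1 to compound 3 (0.10 log units; within the scatter) as its result, so both steps lie within the scatter. The earlier step altered only the length of a carbon chain, whereas this change brings in a nitrogen and a hydrogen-bond donor on the carbonyl carbon whose other neighbour is the amide-type nitrogen, and the three compounds still cannot be ordered. Nothing measured here offers an explanation for this result.

It remains open whether an amine, a carboxylic acid or a longer chain on this carbonyl carbon would also fall within the scatter of these compounds. These compounds also leave open how a change elsewhere on the shared core would read in this assay as a measure of toxicity.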